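The compounds below may be only part of what the source reports. "The series", "measured", "known", "first", "only" and "open" are said of these compounds alone.

Measured so far:
- compound 1, `COc1cccc(OC)c1C(=O)Nc1c[nH]nc1C(=O)NCc1ccccc1`: 50000 nM
- compound 2, `CCc1ccccc1C(=O)Nc1c[nH]nc1C(=O)N[C@H]1CC[C@H](OC)CC1`: 3400 nM
- compound 3, `CO[C@H]1CC[C@H](NC(=O)c2n[nH]cc2NC(=O)c2c(C)nc3ccccn23)CC1`: 34000 nM

In an ADME assay on MRC5 cells (Homo sapiens) for inhibition, with a stated time of 72 h (on this read-out lower numbers stand for an effect already at smaller amounts and higher numbers for an effect only at larger amounts of compound), compound 1 gives 50000 nM, the highest of the three numbers; compound 3 lies within the scatter of it, while compound 2 sits well beyond, at a clearly lower number. Compound 4, `COc1cccc(OC)c1C(=O)Nc1c[nH]nc1C(=O)NC1CCC1`, has not yet been measured in this assay. It differs from compound 1 in one place: cyclobutyl in place of benzyl on an amide-type nitrogen. Among the measured compounds shown here, no measured pair isolates this change, so the expected step is small; the step of a 1.1-fold lower number from compound 1 to compound 4 (0.05 log units; within the scatter) is estimated to lie within the usual scatter, with no clear direction. Compound 4 is therefore expected to give about 45000 nM in this assay, in a range from 15000 nM to 140000 nM.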

Compound 4, half-maximal effective concentration: > 50000 nM
Compound 4: a limit, no number; the forecaster's own chance of this, stated with the estimate: 25%; middle value at least 1.1-fold (0.04 log units) away from the limit.
By their numbers in this assay, from the lowest: compound 2; then compounds 3 and 1 (each within the scatter of the next).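

In this assay compound 4 gives > 50000 nM, which is a limit of the assay and not a number. Cyclobutyl in place of benzyl on this amide-type nitrogen therefore gives a number no lower from compound 1 to compound 4 (the limit leaves the size open), so on this core, a four-membered non-aromatic ring of carbon brings no lower number than the benzyl group does. The size of this step cannot be read: the limit of > 50000 nM in this assay, at which 1 of the 4 values shown sits.

From the compounds shown here alone, whether a carboxylic acid, an amine or a longer chain on this nitrogen would bring a lower number with the same core remains open.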